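The source may report more compounds than this note shows. Statements on the series, on what has been measured and on what is new or still open speak of the compounds shown alone.

Within the data shown here, in a functional assay on MCF7 cells (Homo sapiens) for antiproliferative activity, read by MTT assay, with a stated time of 72 h (on this read-out lower numbers stand for stronger inhibition and higher numbers for weaker inhibition), compound 2 (`Cc1ccc(N2CCN(C(=S)SCc3ccc4nc(N)nc(N)c4c3)CC2)c(C)c1`) gives 3120 nM and compound 1 (`COc1ccc(N2CCN(C(=S)SCc3ccc4nc(N)nc(N)c4c3)CC2)cc1`) gives 1580 nM, so compound 2 stands within the scatter of the only other measured value. Compound 3 (`Nc1nc(N)c2cc(CSC(=S)N3CCN(c4ccc(F)cc4)CC3)ccc2n1`) differs from compound 2 at a single place, the amine nitrogen in a ring, which now bears 4-fluorophenyl: 4-fluorophenyl in place of 2,4-dimethylphenyl on an amine nitrogen in a ring. Among the measured compounds shown here, the one measured step at that place, a 2.0-fold higher number from compound 1 to compound 2 (0.30 log units; within the scatter), stayed small, so no change beyond the scatter is expected in this assay. The expected step is a 1.4-fold lower number from compound 2 to compound 3 (0.15 log units; within the scatter). Compound 3 is estimated at 2200 nM, with an expected range of 900 nM to 5500 nM.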

Compound 3, half-maximal inhibitory concentration: 1920 nM
The estimate for compound 3 lay 1.1-fold (0.06 log units) above the measured number; the range from low to high includes it.
By their numbers in this assay, from the lowest: compounds 1, 3 and 2 (each within the scatter of the next).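

In this assay the amine nitrogen in a ring accepts 4-fluorophenyl in place of 2,4-dimethylphenyl with the numbers staying within the scatter (the step is a 1.6-fold lower number from compound 2 to compound 3 (0.21 log units; within the scatter)). Fluoro in place of methoxy on an aromatic carbon also stays within the scatter (the step is a 1.2-fold higher number from compound 1 to compound 3 (0.08 log units; within the scatter)), so all three substituted phenyl groups read alike here. Nothing available bears on why these values stay so close. The compounds shown leave open whether a cyclohexyl or a plain methyl on that nitrogen, or a phenyl carrying a carboxylic acid or an amine, would move the number beyond the scatter.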